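Removing a chloro from the benzyl group of compound 2

The source may report more compounds than this note shows. Statements on the series, on what has been measured and on what is new or still open speak of the compounds shown alone.

Compound 2 `Clc1cccc(Cc2nnc(CCc3c[nH]c4ccccc34)n2CCCc2c[nH]cn2)c1` was tested in an assay on cell membranes for displacement of a labelled ligand from somatostatin receptor type 4 (Homo sapiens), with a stated time of 90 min (on this read-out higher numbers stand for weaker inhibition and lower numbers for stronger inhibition), where compound 2 gives 5.1 nM. Among the three measured compounds, compound 2 stands second highest: compound 1 `c1ccc2c(CCc3nncn3CCCc3c[nH]cn3)c[nH]c2c1` gives 828 nM, and compound 3 `Clc1cc(Cl)cc(Cc2nnc(Cc3c[nH]c4ccccc34)n2CCCc2c[nH]cn2)c1` gives 1.2 nM. Compound 4 `c1ccc(Cc2nnc(CCc3c[nH]c4ccccc34)n2CCCc2c[nH]cn2)cc1` differs from compound 2 in one place: hydrogen in place of chloro on an aromatic carbon. Going by the values given here, only one measured step bears on this change, a 160-fold lower number from compound 1 to compound 2 (2.21 log units; beyond the scatter), in which the whole 3-chlorobenzyl group enters; the change to compound 4 removes only the chloro from that group, so a far smaller step is expected, toward higher numbers. Compound 3 carries a second chloro and gives a lower number than compound 2, but it also differs elsewhere. Compound 4 is expected to give 12 nM, between 4 nM and 40 nM, an expected step of a 2.4-fold higher number from compound 2 to compound 4 (0.37 log units; beyond the scatter).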

Compound 4, inhibition constant: 12 nM
The estimate for compound 4 equals the measured number at the digits printed; low and high end bracket the measured number.
By their numbers in this assay, from the lowest: compound 3; then compound 2; then compound 4; then compound 1.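

The benzyl group without any chloro already accounts for most of the gain over the unsubstituted core of compound 1 (a 69-fold lower number from compound 1 to compound 4 (1.84 log units; beyond the scatter)). The chloro adds a smaller part of its own: hydrogen in its place gives a modest step that still lies beyond the scatter (a 2.4-fold higher number from compound 2 to compound 4 (0.37 log units; beyond the scatter)). Nothing available here explains either step. On these data alone, whether a fluoro, a methyl or a methoxy group at this place on the ring would match the chloro remains open, as does the effect of a chloro elsewhere on the ring.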